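This account rests on a few compounds, and the source may have more. Where it says the series, first, only, none or still open, it means among the compounds named here.

Measured so far, with half-maximal inhibitory concentrations:
compound 1 `COc1ccc(CN(C(=O)CSc2nc3ccccc3s2)c2cc(OC)c(OC)c(OC)c2)cc1C`: 34300 nM
compound 2 `COc1ccc(CN(C(=O)CSc2nc3ccccc3s2)c2cc(OC)c(OC)c(OC)c2)cc1O`: 2110 nM
compound 3 `COc1ccc(CN(C(=O)CSc2nc3ccccc3s2)c2cc(OC)c(OC)c(OC)c2)cc1N`: 7510 nM

In a functional assay on PC-3 cells (Homo sapiens) for antiproliferative activity, read by MTT assay, with a stated time of 48 h (on this read-out lower numbers stand for stronger inhibition and higher numbers for weaker inhibition), compound 1 stands at the highest number of the three. Its nearest neighbour is compound 3, reached by a 4.6-fold lower number from compound 1 to compound 3 (0.66 log units; beyond the scatter); furthest is compound 2, reached by a 16-fold lower number from compound 1 to compound 2 (1.21 log units; beyond the scatter). Between the two substituted analogues the order runs a 3.6-fold higher number from compound 2 to compound 3 (0.55 log units; beyond the scatter).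

Compound 4 `COc1ccc(CN(C(=O)CSc2nc3ccccc3s2)c2cc(OC)c(OC)c(OC)c2)cc1N=[N+]=[N-]` is not yet measured. It differs from compound 1 as follows: azido in place of methyl on an aromatic carbon. The two measured steps that bear on it are the same exchange of methyl at the same aromatic carbon for a heteroatom-bearing group, once for hydroxy and once for amino; both lowered the number in this assay, one by a large margin, one by a modest one. Azido is neither of those groups, and it brings an acceptor but no donor, so the smaller of the two precedents is taken as the closer guide. A modest downward step is therefore expected, a 3.4-fold lower number from compound 1 to compound 4 (0.54 log units; beyond the scatter), though with wide uncertainty. For compound 4 the estimate in this assay is 10000 nM, with a range from 3500 nM to 30000 nM.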

Compound 4, half-maximal inhibitory concentration: 14400 nM
Beside the measured number, compound 4's estimate is 1.4-fold (0.16 log units) below it, and the stated range covers the measured number.
By their numbers in this assay, from the lowest: compound 2; then compounds 3 and 4 (each within the scatter of the next); then compound 1.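

In this assay azido is a third replacement for methyl on this aromatic carbon, ortho to a methoxy group, that lowers the number (a 2.4-fold lower number from compound 1 to compound 4 (0.38 log units; beyond the scatter)), so the drop from methyl is no longer confined to hydroxy and amino, and none of the replacements shown goes against it. Among the compounds shown here, the azido and amino compounds cannot be separated (a 1.9-fold higher number from compound 3 to compound 4 (0.28 log units; within the scatter)), whereas hydroxy remains clearly ahead of azido (a 6.8-fold higher number from compound 2 to compound 4 (0.83 log units; beyond the scatter)), leaving compound 2 as the only compound here with a step beyond the scatter in the lower direction to each of the others. No data shown here bear on the reason for this order.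

The compounds shown leave open where fluoro, chloro, nitrile or a carboxylic acid would fall on this carbon relative to the hydroxy of compound 2 and the methyl of compound 1. They also leave open whether capping the hydroxy as a methoxy or the amino as an acetamide would retain the lower numbers, and whether the same order would hold on a cell line other than the one used here.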